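This account rests on a few compounds, and the source may have more. Where it says the series, first, only, none or still open, it means among the compounds named here.

Compound 1 `Cc1c(C(=O)Nc2ccc(Oc3ncnc4[nH]cc(-c5ccccc5)c34)c(F)c2)c(=O)c2cc(F)ccc2n1C` was tested in an assay on isolated protein for inhibition of tyrosine-protein kinase receptor UFO (Homo sapiens), read by FRET and Z'-LYTE, with a stated time of 1.5 h; on this read-out higher numbers stand for weaker inhibition and lower numbers for stronger inhibition. In this assay compound 1 gives only a limit, > 10000 nM, and no number. It sits at the limit of > 10000 nM in this assay, at which 1 of the 3 values shown sits. Compound 2 `CCn1c(C)c(C(=O)Nc2ccc(Oc3ncnc4[nH]cc(-c5ccccc5)c34)c(F)c2)c(=O)c2cc(C)ccc21` gives 150 nM in this assay, and compound 3 `CCc1ccc2c(c1)c(=O)c(C(=O)Nc1ccc(Oc3ncnc4cc(OC)c(OC)cc34)c(F)c1)c(C)n2C` gives 4 nM. Among the compounds with values here, neither of these differs from compound 1 in a single place, so no step is counted between them and compound 1. Compound 4 `Cc1c(C(=O)Nc2ccc(Oc3ncnc4[nH]cc(-c5ccccc5)c34)c(F)c2)c(=O)c2cc(OC(F)(F)F)ccc2n1C` has not yet been measured. It differs from compound 1 by trifluoromethoxy in place of fluoro on an aromatic carbon. Within the data shown here, no measured step covers this change, so the expectation rests on compound 1 alone. A modest move toward stronger inhibition, an at least 1.6-fold lower number from compound 1 to compound 4 (0.22 log units; that floor lies within the scatter), is expected, though a result again at the limit would not surprise. Compound 4 is expected to give about 6000 nM, somewhere between 1000 nM and 30000 nM.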

Compound 4, half-maximal inhibitory concentration: 74 nM
The estimate for compound 4 lay 81-fold (1.91 log units) above the measured number; measured number below the stated range.
By their numbers in this assay, from the lowest: compound 3; then compound 4; then compound 2. At a limit, above all of these: compound 1.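

In this assay, trifluoromethoxy in place of fluoro on this aromatic carbon gives an at least 130-fold lower number from compound 1 to compound 4 (2.13 log units; beyond the scatter), so on the core of compound 1 this position can decide between inhibition that is measurable and inhibition that is not. The size of this step is only a floor, because compound 1 gives a limit and not a number: the limit of > 10000 nM in this assay, at which 1 of the 4 values shown sits.

From the compounds shown here alone, what a methoxy or a trifluoromethyl group would give at this position stays open. So does whether the oxygen or the fluorines of the new group carry the step.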